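This account rests on a few compounds, and the source may have more. Where it says the series, first, only, none or still open, it means among the compounds named here.

Three compounds share one core, an amide of a diamine joined through a sulfur-linked thiocarbonyl to a varying amine, and each has been tested in a functional assay on A-375 cells (Homo sapiens) for antiproliferative activity, read by CCK-8 assay, with a stated time of 72 h, tested at 8 uM; a lower number here means a weaker effect, a higher number a stronger effect of the compound at the concentration tested. Compound 1, `Nc1ccccc1NC(=O)c1ccc(CSC(=S)N2CCc3cc([N+](=O)[O-])ccc32)cc1`, gives 29.5%. Compound 2, `CCN(Cc1ccncc1)C(=S)SCc1ccc(C(=O)Nc2ccccc2N)cc1`, gives 86.2%. Compound 3, `Nc1ccccc1NC(=O)c1ccc(CSC(=S)N2CCCc3ccccc32)cc1`, gives 81.5%, the second highest of the three numbers; its nearest neighbour is compound 2, whose number lies within the scatter of it, while compound 1 lies far below it, beyond the scatter.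

Compound 4, `CN(C(=S)SCc1ccc(C(=O)Nc2ccccc2N)cc1)c1cccnc1`, is not yet measured. It differs from compound 3 in one place: methyl(pyridin-3-yl)amino in place of 1,2,3,4-tetrahydroquinolin-1-yl on a thiocarbonyl carbon.

Within the data shown here, only one measured step bears on this change, the one from the acyclic amine of compound 2 to the ring amine of compound 3, which moved the read-out by a number 4.7 percentage points lower from compound 2 to compound 3 (within the scatter). Compound 4 returns to an acyclic amine carrying a pyridine, so the expected outcome is a step of no clear size, that is, no change beyond the scatter, because a number 4.7 percentage points lower from compound 2 to compound 3 (within the scatter) was itself within the scatter. The step from compound 3 to compound 4 is therefore estimated as a number 1.5 percentage points lower from compound 3 to compound 4 (within the scatter). Compound 4 is expected to reach 80%, within a range from 60% to 92%.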

Compound 4, a percentage reported as inhibition, at one concentration (the size of the read-out at that concentration, not a potency): 87.7%
Estimate against measurement, compound 4: 7.7 percentage points below; measured number inside the range.
By their numbers in this assay, from the lowest: compound 1; then compounds 3, 2 and 4 (each within the scatter of the next).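

In this assay the exchange of 1,2,3,4-tetrahydroquinolin-1-yl for methyl(pyridin-3-yl)amino on the thiocarbonyl carbon gives a number 6.2 percentage points higher from compound 3 to compound 4 (within the scatter) and so shows that this position accepts a third, quite different amine without a clear loss of effect. Measured against the other amine that carries a pyridine ring, the new group gives a number 1.5 percentage points higher from compound 2 to compound 4 (within the scatter), so compound 2, compound 3 and compound 4 all sit at one level, and the exception among the compounds shown is compound 1 (29.5%). The entering group has fewer heavy atoms than the one it replaces and adds a hydrogen-bond acceptor, yet the read-out stays within the scatter, and nothing measured here explains why these amines give such similar numbers.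

The read-out comes from a single concentration, so compound 2, compound 3 and compound 4 could still show a stronger or weaker effect at other concentrations, which a full concentration series would show. On these data alone, it also remains open how a plain phenyl ring in place of the pyridine, or a morpholine or a piperidine on the thiocarbonyl carbon, would compare.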